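A few compounds are considered here, and "the series" means these few. Any claim that something is new, unique, unknown or untested is made for them only; others in the source may bear on it.

Measured in an ADME assay on Vero cells (Chlorocebus sabaeus) for cytotoxicity; a higher number here means that more compound is tolerated, a lower number that less compound is tolerated:
Compound 1 `C[C@]1(CO)O[C@@H](n2cc(I)c3c(N)ncnc32)[C@H](O)[C@@H]1O`: 8080 nM.
Compound 2 `C[C@]1(CO)O[C@@H](n2cc(-c3ccco3)c3c(N)ncnc32)[C@H](O)[C@@H]1O`: > 50000 nM, a limit of this assay.
Compound 3 `C[C@]1(CO)O[C@@H](n2cc(-c3cc4ccccc4o3)c3c(N)ncnc32)[C@H](O)[C@@H]1O`: 27000 nM.

Compound 3 holds the highest of the two numbers shown; compound 1 is nearest, the step being a 3.3-fold higher number from compound 1 to compound 3 (0.52 log units; beyond the scatter). Compound 2 sits at the limit (the limit of > 50000 nM in this assay, at which 1 of the 3 values shown sits). Compound 4 `C#Cc1cn([C@@H]2O[C@](C)(CO)[C@@H](O)[C@H]2O)c2ncnc(N)c12` differs from compound 3 by ethynyl in place of 1-benzofuran-2-yl on an aromatic carbon. Within the data shown here, no measured step replaces an aryl group with ethynyl; the steps that bear on it are an at least 6.1-fold higher number from compound 1 to compound 2 (0.79 log units; beyond the scatter) and a 3.3-fold higher number from compound 1 to compound 3 (0.52 log units; beyond the scatter), where iodo gave the lower number, and an at least 1.8-fold lower number from compound 2 to compound 3 (0.26 log units; that floor lies within the scatter) between the two aryl groups. A modest lower number in this assay is therefore expected for compound 4, estimated at 15000 nM (range 5000 nM to 45000 nM). The expected step is a 1.8-fold lower number from compound 3 to compound 4 (0.26 log units; within the scatter).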

Compound 4, half-maximal cytotoxic concentration: 13400 nM
The estimate for compound 4 lay 1.1-fold (0.05 log units) above the measured number; the measured number falls inside the stated range.
By their numbers in this assay, from the lowest: compounds 1, 4 and 3 (each within the scatter of the next, the first and the last beyond it). At a limit, above all of these: compound 2.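

In this assay ethynyl, a group with no ring, cannot be placed apart from either iodo or 1-benzofuran-2-yl at this position: a 1.7-fold higher number from compound 1 to compound 4 (0.22 log units; within the scatter) and a 2.0-fold lower number from compound 3 to compound 4 (0.30 log units; within the scatter) both lie within the scatter. Furan-2-yl alone stands clear of ethynyl, with an at least 3.7-fold lower number from compound 2 to compound 4 (0.57 log units; beyond the scatter). Compound 2 holds a limit here, not a number: the limit of > 50000 nM in this assay, at which 1 of the 4 values shown sits.

On these data alone, how far compound 2 lies past that limit stays open. So does how an amine, a carboxylic acid or a longer alkyne chain at this position would read in this assay.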